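Urea series: aryl swap on the ring nitrogen

The source may hold more compounds than are shown below. What is called first, only, known or untested is meant among the compounds shown, and "the series" means these compounds.

Measured so far in a functional assay on NCI-H520 cells (Homo sapiens) for inhibition, read by MTT assay, with a stated time of 48 h, tested at 10 uM; a higher number here means more inhibition at the concentration tested (going by the name of the read-out), a lower number less inhibition:
compound 1, `COc1ccc(Br)cc1Nc1cc(NC(=O)Nc2c(Cl)cccc2Cl)ncn1`, 45%
compound 2, `COc1cc(NC(=O)Nc2cc(Nc3cc(Br)ccc3OC)ncn2)cc(OC)c1`, 43.5%
compound 3, `COc1ccc(OC)c(Nc2cc(NC(=O)Nc3c(Cl)cccc3Cl)ncn2)c1`, 74%

Compound 2 and compound 1 lie within the scatter of each other, a number 1.5 percentage points lower from compound 1 to compound 2 (within the scatter). For the measured compounds named here, compound 3 sits apart from both, a number 29 percentage points higher from compound 1 to compound 3 (beyond the scatter), the only step here beyond the scatter. Compound 4, `COc1cc(NC(=O)Nc2cc(Nc3ccc(C)c(F)c3)ncn2)cc(OC)c1`, is not yet measured. It differs from compound 2 in one place: 3-fluoro-4-methylphenyl in place of 5-bromo-2-methoxyphenyl on a nitrogen on an aromatic ring. Going by the values given here, no measured step changes this aryl group as a whole; the step from compound 1 to compound 3 touches it, and that exchange on an aromatic carbon moved the read-out modestly. The step to compound 4 is therefore expected to be modest and of uncertain direction, a number 6.5 percentage points higher from compound 2 to compound 4 (within the scatter). Compound 4 is estimated at 50%, within 25% to 75%.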

Compound 4, a percentage reported as inhibition, at one concentration (the size of the read-out at that concentration, not a potency): 30.6%
Estimate against measurement, compound 4: 19.4 percentage points above; measured number inside the range.
By their numbers in this assay, from the lowest: compound 4; then compounds 2 and 1 (each within the scatter of the next); then compound 3.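

In this assay, the read-out responds to replacing the whole aryl group on this nitrogen: 3-fluoro-4-methylphenyl in place of 5-bromo-2-methoxyphenyl gives a number 12.9 percentage points lower from compound 2 to compound 4 (beyond the scatter). The earlier steps shown here changed only a single substituent on this aryl group or the group on the amide-type nitrogen, whereas this one exchanges the entire aryl group. Nothing available explains this difference.

Open, going by these compounds, is whether the same exchange gives a similar step with 2,6-dichlorophenyl on the amide-type nitrogen. Also open, on these data alone, is how an aminomethyl or carboxylic acid group on this aryl ring would read.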